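Methyl for chloro on the anilino-bearing ring: cytotoxicity notes

The compounds below may be only part of what the source reports. "The series", "measured", "known", "first", "only" and "open" are said of these compounds alone.

The shared core is seen in compound 1 `Cc1ccc(-c2nn(-c3ccccc3)cc2CNc2ccccc2)cc1`, compound 2 `FC(F)(F)c1ccc(NCc2cn(-c3ccccc3)nc2-c2ccc(Br)cc2)cc1` and compound 3 `Clc1ccc(NCc2cn(-c3ccccc3)nc2-c2ccc(Cl)cc2)cc1`, all three tested in an ADME assay on MT4 cells (Homo sapiens) for cytotoxicity, read by MTT assay, with a stated time of 96 h; on this read-out lower numbers stand for higher toxicity in this test and higher numbers for lower toxicity in this test. Compound 1 gives > 100000 nM, which is a limit of the assay and not a number. Compound 2 likewise reaches only the limit of > 100000 nM in this assay. Compound 3 also stops at the limit of > 100000 nM in this assay. Where compound 3 stands is therefore set by the limit of > 100000 nM in this assay, at which 3 of the 3 values shown sit, and nothing in the numbers separates it from compound 1 or compound 2. Within the data shown here, no step between measured compounds that differ in one place is available, so no measured step in this assay speaks to the change now at hand. Compound 4 `Cc1ccc(NCc2cn(-c3ccccc3)nc2-c2ccc(Cl)cc2)cc1` differs from compound 3 by methyl in place of chloro on an aromatic carbon. Because of the limit of > 100000 nM in this assay, at which 3 of the 3 values shown sit, the expected step in this assay is none beyond the scatter, namely a step that the limit leaves unreadable from compound 3 to compound 4. Compound 4 is accordingly estimated at 150000 nM in this assay, between 100000 nM and 400000 nM, most likely reported again as a limit.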

Compound 4, half-maximal cytotoxic concentration: > 100000 nM
Compound 4: only a limit was reported; the forecaster's own chance of this, stated with the estimate: 85%; the middle value does not contradict the limit.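

Compound 4 gives > 100000 nM in this assay, a limit and not a number. No step can be read between compound 3 and compound 4: the limit of > 100000 nM in this assay, at which 4 of the 4 values shown sit.

The compounds shown leave open whether any change on the shared core brings cytotoxicity into a readable range in this assay.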